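A few compounds are considered here, and "the series" means these few. Any claim that something is new, unique, unknown or untested is made for them only; others in the source may bear on it.

Going by the values given here, compound 2 `O=c1c(OCc2cccc(Br)c2)c(-c2ccccc2)oc2cc(O)cc(O)c12` stands at the lower of the two numbers so far in an ADME assay on Huh-5-2 cells (Homo sapiens) for cytotoxicity, read by WST assay, with a stated time of 3 days; a lower number here means that less compound is tolerated, a higher number that more compound is tolerated; its value there is 15000 nM. Its nearest neighbour is compound 1 `Cc1ccccc1COc1c(-c2ccccc2)oc2cc(O)cc(O)c2c1=O`, which in this assay gives 55000 nM. Among the compounds with values here, the one measured step connecting them, a 3.7-fold lower number from compound 1 to compound 2 (0.56 log units; beyond the scatter), exchanged the whole benzyl substituent pattern in one move and is the only comparison available for the next change.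

Compound 3 `Cc1cccc(COc2c(-c3ccccc3)oc3cc(O)cc(O)c3c2=O)c1` differs from compound 2 in a single place: methyl in place of bromo on an aromatic carbon. This puts a methyl where compound 1 carries one, but on the 3-position rather than the 2-position, so the step from compound 2 to compound 3 separates the nature of the group from its position, which the step from compound 1 to compound 2 did not do.

Given that the methyl-bearing compound 1 sits at 55000 nM and the bromo-bearing compound 2 at 15000 nM, a shift back toward compound 1 is expected for compound 3, of size a 2.0-fold higher number from compound 2 to compound 3 (0.30 log units; within the scatter), though position also shifted in that measured step. Compound 3 is therefore estimated at 30000 nM, with a range of 12000 nM to 75000 nM.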

Compound 3, half-maximal cytotoxic concentration: 29000 nM
Compound 3: the middle estimate sits 1.0-fold (0.01 log units) above what was measured; the measured number falls inside the stated range.
By their numbers in this assay, from the lowest: compounds 2, 3 and 1 (each within the scatter of the next, the first and the last beyond it).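

With methyl in place of bromo on the aromatic carbon, this assay shows a 1.9-fold higher number from compound 2 to compound 3 (0.29 log units; within the scatter) and so no readable effect of exchanging these two groups at this place. Exchanging 2-methylphenyl for 3-methylphenyl likewise shows a 1.9-fold lower number from compound 1 to compound 3 (0.28 log units; within the scatter) and so no readable effect of where the methyl stands on the ring. Going by these compounds alone, the gap between compound 1 and compound 2, the only step in this set beyond the scatter, therefore divides into two steps that each stay within it, and neither the identity of the group nor its place can be named alone as the source of that gap.

No measurement available here bears on what lies behind these numbers.

Open, from the compounds shown here alone, is how bromo behaves on the carbon that carries the methyl in compound 1, the one combination that would test group and place together on the same benzyl pattern. Also open, going by these compounds, is whether an amine, a carboxylic acid or a methoxy group on this aromatic carbon would move the number beyond the scatter, which neither bromo nor methyl has done relative to compound 3.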